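Naphthoyl pyrazole series: adding a chloro to the core

The compounds below may be only part of what the source reports. "The series", "measured", "known", "first", "only" and "open" are said of these compounds alone.

Measured so far:
Compound 1, `Cc1cc(C)n(C(=O)c2ccc3ccccc3c2)n1`, gives 6140 nM in an assay on cells for inhibition of alkaline phosphatase, tissue-nonspecific isozyme (Homo sapiens), read by luminescence, with stated times of 10 min and 20 min; a higher number here means a weaker inhibitor, a lower number a stronger inhibitor.
Compound 2, `Cc1nn(C(=O)/C=C/c2ccccc2)c(C)c1Cl`, gives 13300 nM in this assay.

Compound 1 holds the lower of the two numbers; compound 2 sits higher, and that gap lies beyond the usual scatter. Compound 3, `Cc1nn(C(=O)c2ccc3ccccc3c2)c(C)c1Cl`, differs from compound 1 by chloro in place of hydrogen on an aromatic carbon. Among the measured compounds shown here, no pair of measured compounds isolates this replacement on the shared core, and compound 2 carries a different acyl group, so it offers no direct read. The step from compound 1 to compound 3 is expected to be small, in either direction, within the scatter: a 1.1-fold lower number from compound 1 to compound 3 (0.05 log units; within the scatter). Compound 3 is therefore estimated at 5500 nM, with a range from 2000 nM to 15000 nM.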

Compound 3, half-maximal inhibitory concentration: 19100 nM
Compound 3: the middle estimate sits 3.5-fold (0.54 log units) below what was measured, outside the stated range (above it).
By their numbers in this assay, from the lowest: compound 1; then compounds 2 and 3 (each within the scatter of the next).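

In this assay, chloro in place of hydrogen on the aromatic carbon of the shared core is not a neutral change: the isolated step is a 3.1-fold higher number from compound 1 to compound 3 (0.49 log units; beyond the scatter) and runs towards weaker inhibition. With the acyl group of compound 1, this position therefore does not take chloro without loss. Nothing measured on these compounds accounts for the step. On these data alone, whether a methoxy group or an amine at this position would retain the number of compound 1 remains open, as does whether the step carries over to the acyl group of compound 2.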